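Extending the morpholinyl side chain of compound 3

The compounds below may be only part of what the source reports. "The series", "measured", "known", "first", "only" and "open" are said of these compounds alone.

compound 1 `COc1cc(N2CCN(C(=O)N3CCC(O)C3)CC2)ccc1Nc1nc(NC2CCCCC2)c2nc[nH]c2n1`: 27 nM
compound 2 `COc1cc(N2CCC(C(=O)N3CCC(N(C)C)C3)CC2)ccc1Nc1nc(NC2CCCCC2)c2nc[nH]c2n1`: 58 nM
compound 3 `COc1cc(N2CCC(C(=O)N3CCOCC3)CC2)ccc1Nc1nc(NC2CCCCC2)c2nc[nH]c2n1`: 50 nM

In a functional assay on HCT-116 cells (Homo sapiens) for cytotoxicity (on this read-out higher numbers stand for weaker inhibition and lower numbers for stronger inhibition), compound 3 gives 50 nM, which lies within the usual scatter of both other compounds, so the three cannot be ranked. The untested compound 4 `COc1cc(N2CCC(CC(=O)N3CCOCC3)CC2)ccc1Nc1nc(NC2CCCCC2)c2nc[nH]c2n1` carries ((morpholin-4-yl)carbonyl)methyl in place of (morpholin-4-yl)carbonyl on a saturated ring carbon. Within the data shown here, no measured step tests this exact change. The nearest guide is a 1.2-fold lower number from compound 2 to compound 3 (0.06 log units; within the scatter), where morpholin-4-yl replaced 3-(dimethylamino)pyrrolidin-1-yl on a carbonyl carbon. That guide is indirect, so the expectation is no step beyond the scatter. The expected step is a 1.1-fold higher number from compound 3 to compound 4 (0.04 log units; within the scatter). For compound 4 the estimate is 55 nM, with an expected range from 22 nM to 140 nM.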

Compound 4, half-maximal inhibitory concentration: 36 nM
Estimate against measurement, compound 4: 1.5-fold (0.18 log units) above, within the range that was stated.
By their numbers in this assay, from the lowest: compounds 1, 4, 3 and 2 (each within the scatter of the next, the first and the last beyond it).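

Going to ((morpholin-4-yl)carbonyl)methyl on this saturated ring carbon gives a 1.4-fold lower number from compound 3 to compound 4 (0.14 log units; within the scatter) in this assay, so the extra carbon in the side chain produces no change that can be told from scatter. The step of a 1.6-fold lower number from compound 2 to compound 4 (0.21 log units; within the scatter) also stays within the scatter, though it changes both the chain and the group on the carbonyl. Nothing available bears on the reason for this result. 

From the compounds shown here alone, how a longer chain before the carbonyl would read out at this ring carbon remains open. So does the effect of a carboxylic acid in place of the morpholin-4-yl amide.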